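The source may report more compounds than this note shows. Statements on the series, on what has been measured and on what is new or still open speak of the compounds shown alone.

In a functional assay on COLO 205 cells (Homo sapiens) for cytotoxicity, read by MTT assay, with a stated time of 48 h (a lower number here means a stronger inhibitor, a higher number a weaker inhibitor), compound 3 `Fc1ccc(Nc2nc(-c3cccc(F)c3)nc3ccc(F)cc23)cc1` returns only the limit of the measurement, > 50000 nM. Compound 1 `Fc1cccc(-c2nc(Nc3ccccc3)c3ccccc3n2)c1` likewise gives a limit in this assay, > 50000 nM. Compound 2 `Fc1ccc2nc(-c3ccccc3)nc(Nc3ccccc3)c2c1` also gives a limit in this assay, > 50000 nM. Every value shown is thus a limit, as the limit of > 50000 nM in this assay, at which 3 of the 3 values shown sit, records, and compound 3 cannot be placed against the others beyond that. Compound 4 `Fc1cccc(-c2nc(Nc3ccc(Cl)cc3)c3cc(F)ccc3n2)c1` differs from compound 3 by chloro in place of fluoro on an aromatic carbon. Among the measured compounds shown here, no measured step of this kind is available, and in this assay the expected step is a number no higher from compound 3 to compound 4 (the limit leaves the size open), no change beyond the scatter. Compound 4 is therefore estimated at about 50000 nM in this assay, ranging from 20000 nM to 120000 nM, most likely again reported only as a limit.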

Compound 4, half-maximal inhibitory concentration: 32600 nM
The estimate for compound 4 lay 1.5-fold (0.19 log units) above the measured number; the range from low to high includes it.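

In this assay, the change from (4-fluorophenyl)amino to (4-chlorophenyl)amino gives an at least 1.5-fold lower number from compound 3 to compound 4 (0.18 log units; that floor lies within the scatter). Compound 4 is thus the only compound shown with a number rather than a limit, so this position is one where a single atom can bring the read-out within the measured range. How large the step really is stays unknown because compound 3 carries only a limit: the limit of > 50000 nM in this assay, at which 3 of the 4 values shown sit.

On these data alone, whether bromo, a methoxy group or an amine at this position would give a lower number remains open. So does the contribution of the other fluoro groups in compound 4.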